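Cyclopentane dicarboxamide series: tertiary versus anilide amide

A few compounds are considered here, and "the series" means these few. Any claim that something is new, unique, unknown or untested is made for them only; others in the source may bear on it.

Measured so far:
compound 1 `CC1CCN(C(=O)[C@@H]2C[C@H](S(=O)(=O)c3ccccc3)C[C@H]2C(=O)NC2(C#N)CC2)CC1`: 0.5 nM
compound 2 `N#CC1(NC(=O)[C@@H]2C[C@@H](S(=O)(=O)c3ccccc3)C[C@H]2C(=O)Nc2ccc(F)cc2)CC1`: 26 nM

Within the data shown here, in an assay on isolated protein for inhibition of cathepsin S (Homo sapiens), read by fluorescence, with a stated time of 20 min (on this read-out higher numbers stand for weaker inhibition and lower numbers for stronger inhibition), compound 2 stands as the highest of the two numbers; its nearest neighbour is compound 1, and the single step of a 52-fold higher number from compound 1 to compound 2 (1.72 log units; beyond the scatter) lies beyond the scatter. Compound 3 `N#CC1(NC(=O)[C@@H]2C[C@@H](S(=O)(=O)c3ccccc3)C[C@H]2C(=O)N2CCC2)CC1` differs from compound 2 by azetidin-1-yl in place of (4-fluorophenyl)amino on a carbonyl carbon. That step bears the same direction as returning toward compound 1, where the carbonyl carries a saturated nitrogen ring, so a large decrease is expected in this assay, though perhaps not the whole way back. The estimated step of an 8.7-fold lower number from compound 2 to compound 3 (0.94 log units; beyond the scatter) is expected accordingly; compound 3 is estimated at 3 nM with a range of 0.8 nM to 12 nM.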

Compound 3, half-maximal inhibitory concentration: 10 nM
For compound 3 the middle estimate is 3.3-fold (0.52 log units) below the measured one; low and high end bracket the measured number.
By their numbers in this assay, from the lowest: compound 1; then compound 3; then compound 2.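

In this assay azetidin-1-yl on this carbonyl carbon gives only a 2.6-fold lower number from compound 2 to compound 3 (0.41 log units; beyond the scatter), whereas a 20-fold higher number from compound 1 to compound 3 (1.30 log units; beyond the scatter) remains a large step. A saturated nitrogen ring at this position is therefore not enough to reach the number of compound 1, and the two rings, azetidin-1-yl and 4-methylpiperidin-1-yl, are far apart. Nothing available accounts for either step.

Open, from the compounds shown here alone, is whether the gap follows ring size or the methyl group. Pyrrolidin-1-yl and unsubstituted piperidin-1-yl on the same carbonyl would separate the two.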